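Fluoroethenyl for methylbutenyl amide on a second core

The source may report more compounds than this note shows. Statements on the series, on what has been measured and on what is new or still open speak of the compounds shown alone.

Compound 1 `CC(C)/C=C/C(=O)Nc1cccc(Oc2nc(Nc3ccn(C)n3)nc3c2CSCC3)c1`, compound 2 `C=C(F)C(=O)Nc1cccc(Oc2nc(Nc3ccn(C)n3)nc3c2CSCC3)c1` and compound 3 `COc1cccc(Nc2nc3c(c(Oc4cccc(NC(=O)/C=C/C(C)C)c4)n2)CSCC3)c1` have been measured. In a functional assay on A549 cells (Homo sapiens) for antiproliferative activity, read by MTT assay, with a stated time of 72 h (a higher number here means a weaker inhibitor, a lower number a stronger inhibitor), compound 1 gives 33500 nM. Compound 2 reaches only the limit of this assay, > 50000 nM, and no number. In this assay compound 3 gives 25300 nM.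

Compound 4 `C=C(F)C(=O)Nc1cccc(Oc2nc(Nc3cccc(OC)c3)nc3c2CSCC3)c1` has not been measured. It differs from compound 3 by 1-fluoroethenyl in place of 3-methylbut-1-en-1-yl on a carbonyl carbon. The same change, (1-fluoroethenyl in place of 3-methylbut-1-en-1-yl on a carbonyl carbon), takes compound 1 to compound 2 and gave an at least 1.4-fold higher number from compound 1 to compound 2 (0.17 log units; that floor lies within the scatter); its floor rests on (the limit of > 50000 nM in this assay, at which 1 of the 3 values shown sits). The two pairs sit on cores that differ by 3-methoxyphenyl in place of 1-methyl-1H-pyrazol-3-yl on a nitrogen on an aromatic ring, a change that gave a 1.3-fold lower number from compound 1 to compound 3 (0.12 log units; within the scatter). The place of the change is the same in both pairs, so it is the same change.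

On that basis the step from compound 3 to compound 4 in this assay is expected to be a 1.8-fold higher number from compound 3 to compound 4 (0.25 log units; within the scatter), a weakening of the same kind as from compound 1 to compound 2, resting on an at least 1.4-fold higher number from compound 1 to compound 2 (0.17 log units; that floor lies within the scatter), with a fair chance that the assay again reports only its limit. Compound 4 is estimated at 45000 nM, between 20000 nM and 110000 nM.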

Compound 4, half-maximal inhibitory concentration: 29600 nM
Compound 4: the middle estimate sits 1.5-fold (0.18 log units) above what was measured; the measured number falls inside the stated range.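

In this assay, putting 1-fluoroethenyl in place of 3-methylbut-1-en-1-yl on the core of compound 3 gives a 1.2-fold higher number from compound 3 to compound 4 (0.07 log units; within the scatter), and beside the earlier step the picture is this: the same change on two cores in this assay, an at least 1.4-fold higher number (0.17 log units; that floor lies within the scatter) from compound 1 to compound 2 and a 1.2-fold higher number (0.07 log units; within the scatter) from compound 3 to compound 4; the limit leaves it open whether they differ. The change of core among the two 1-fluoroethenyl amides gives an at least 1.6-fold lower number from compound 2 to compound 4 (0.22 log units; that floor lies within the scatter), and this step too can only be set beside its earlier counterpart: the same change on two cores in this assay, a 1.3-fold lower number (0.12 log units; within the scatter) from compound 1 to compound 3 and an at least 1.6-fold lower number (0.22 log units; that floor lies within the scatter) from compound 2 to compound 4; the limit leaves it open whether they differ. The result shows that the step on the core of compound 3 stays within the scatter, but it does not show that the change has the same size on both cores, because compound 2 gives only a limit and no number: the limit of > 50000 nM in this assay, at which 1 of the 4 values shown sits.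

The compounds shown leave open how a plain ethenyl group without the fluorine, or a longer chain carrying a dimethylamino group, would read on the carbonyl carbon in this assay. They also leave open whether the change would behave alike with an unsubstituted phenyl on the nitrogen.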